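The source may hold more compounds than are shown below. What is called first, only, known or untested is meant among the compounds shown, and "the series" means these compounds.

Compound 2 `Cc1ccc(-c2cn(-c3ccc(CN4CCCCC4)cc3)nn2)cc1Nc1nccc(-c2cccnc2)n1` gives the lowest number of the two measured in a functional assay on KG-1a cells (Homo sapiens) for inhibition, read by MTT assay, with a stated time of 72 h (on this read-out lower numbers stand for stronger inhibition and higher numbers for weaker inhibition), at 1750 nM. Among the measured compounds shown here, compound 1 `Cc1ccc(-c2cn(-c3ccc(CN4CCN(C)CC4)cc3)nn2)cc1Nc1nccc(-c2cccnc2)n1` gives 6160 nM, so the one measured step, a 3.5-fold lower number from compound 1 to compound 2 (0.55 log units; beyond the scatter), was modest. Compound 3 `Cc1ccc(-c2cn(-c3ccc(CN4CCCC4)cc3)nn2)cc1Nc1nccc(-c2cccnc2)n1` differs from compound 2 by pyrrolidin-1-yl in place of piperidin-1-yl on a saturated chain carbon bound to an aromatic carbon. For the measured compounds named here, only the step from compound 1 to compound 2 bears on this change, and it exchanged one ring for another at the same place; the present exchange is smaller in kind, so no step beyond the scatter is expected, with a 1.1-fold higher number from compound 2 to compound 3 (0.04 log units; within the scatter) as the estimated movement. Compound 3 is therefore estimated at 1900 nM, within a range of 700 nM to 5000 nM.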

Compound 3, half-maximal inhibitory concentration: 5420 nM
Compound 3: middle estimate off by 2.9-fold (0.46 log units), on the low side; measured number above the stated range.
By their numbers in this assay, from the lowest: compound 2; then compounds 3 and 1 (each within the scatter of the next).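

Ring size at this saturated chain carbon counts for more than the small exchange suggested: going from the six-membered piperidin-1-yl to the five-membered pyrrolidin-1-yl gives (a 3.1-fold higher number from compound 2 to compound 3 (0.49 log units; beyond the scatter)). Piperidin-1-yl now stands apart among the three rings, since pyrrolidin-1-yl and 4-methylpiperazin-1-yl show no real difference (a 1.1-fold lower number from compound 1 to compound 3 (0.06 log units; within the scatter)). Nothing available here explains this behaviour. Still open, as far as these compounds go, is whether a seven-membered azepan-1-yl ring, a morpholin-4-yl ring or an open-chain dimethylamino group on the same carbon would match piperidin-1-yl or lower the number further.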